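Methyl for methylsulfonyl on the nitro-bearing ring

This account rests on a few compounds, and the source may have more. Where it says the series, first, only, none or still open, it means among the compounds named here.

For the measured compounds named here, the three measured members are compound 1 `CC(C)n1ncc2c(NCc3ccccc3[N+](=O)[O-])cc(C(F)(F)F)cc21`, compound 2 `O=[N+]([O-])c1ccc(O)cc1CNc1cc(Br)cc2[nH]ncc12` and compound 3 `CS(=O)(=O)c1ccc(CNc2cc(C(F)(F)F)cc3[nH]ncc23)c([N+](=O)O)c1`. In an assay for inhibition of Indoleamine 2,3-dioxygenase 1 (Homo sapiens), with stated times of 10 min and 60 min, tested at 10 uM (a higher number here means a stronger effect of the compound at the concentration tested, a lower number a weaker effect), compound 1 gives 7%, compound 2 gives 92%, and compound 3 gives 63%. Compound 3 thus holds the second highest of the three numbers in this assay: compound 2 stands higher by a margin beyond the scatter, and compound 1 stands lower by a larger margin, also beyond the scatter.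

Compound 4 `Cc1ccc(CNc2cc(C(F)(F)F)cc3[nH]ncc23)c([N+](=O)O)c1` differs from compound 3 in one place: methyl in place of methylsulfonyl on an aromatic carbon. Going by the values given here, no measured pair in the set isolates this change, so its effect is not known from the data. Because compound 3 gives 63% on the shared core, a moderate loss is expected, a number 13 percentage points lower from compound 3 to compound 4 (beyond the scatter), though a step within the scatter cannot be excluded. Compound 4 is estimated at 50% in this assay, with a range from 20% to 80%.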

Compound 4, a percentage reported as inhibition, at one concentration (the size of the read-out at that concentration, not a potency): 36%
The estimate for compound 4 lay 14 percentage points above the measured number; the measured number falls inside the stated range.
By their numbers in this assay, from the lowest: compound 1; then compound 4; then compound 3; then compound 2.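

Placing methyl in place of methylsulfonyl on this aromatic carbon, para to a large group, gives a number 27 percentage points lower from compound 3 to compound 4 (beyond the scatter) in this assay, the first step in the series that isolates a single change. The position is therefore sensitive to its substituent on the shared core, with methylsulfonyl ahead of methyl, yet compound 4 still gives 36%, so the methylsulfonyl group is not needed for a measurable read-out at the concentration tested. Nothing measured here explains the step.

Going by these compounds, two groups at one position give a single comparison, so whether a carboxylic acid, an amine or a methoxy group would fall above, below or between these two remains open. On these data alone, whether the step would hold on a core carrying another group, such as the bromine of compound 2, also remains open.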